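A few compounds are considered here, and "the series" means these few. Any claim that something is new, unique, unknown or untested is made for them only; others in the source may bear on it.

Measured compounds:
compound 1, `CN(C(=O)NC(=O)c1ccc(Cl)cc1Cl)c1nc(C(F)(F)F)c(C(=O)N/N=C/c2cccc(C(F)(F)F)c2)s1`, 10.6 ug/mL
compound 2, `CN(C(=O)NC(=O)c1ccc(Cl)cc1Cl)c1nc(C(F)(F)F)c(C(=O)N/N=C/c2ccccc2C(F)(F)F)s1`, 15.3 ug/mL
compound 3, `CN(C(=O)NC(=O)c1ccccc1F)c1nc(C(F)(F)F)c(C(=O)N/N=C/c2ccccc2C(F)(F)F)s1`, 6.32 ug/mL

The three compounds were tested in a functional assay on A549 cells (Homo sapiens) for inhibition, read by MTT assay, with a stated time of 72 h; a higher number here means a weaker inhibitor, a lower number a stronger inhibitor. Compound 3 gives the lowest of the three numbers, but its gap to compound 1 is within the scatter, so no order between those two can be read. Two single changes connect the measured compounds. The first is 2-fluorophenyl in place of 2,4-dichlorophenyl on a carbonyl carbon, which gave a 2.4-fold lower number from compound 2 to compound 3 (0.38 log units; beyond the scatter). The second is 3-(trifluoromethyl)phenyl in place of 2-(trifluoromethyl)phenyl on a carbon with a double bond to nitrogen, which gave a 1.4-fold lower number from compound 2 to compound 1 (0.16 log units; within the scatter).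

Compound 4, `CN(C(=O)NC(=O)c1ccccc1F)c1nc(C(F)(F)F)c(C(=O)N/N=C/c2cccc(C(F)(F)F)c2)s1`, has not yet been measured. It differs from compound 3 by 3-(trifluoromethyl)phenyl in place of 2-(trifluoromethyl)phenyl on a carbon with a double bond to nitrogen. This is the same change that leads from compound 2 to compound 1; the place lines read the same word for word, so the change is the same. The cores of the two pairs differ by 2-fluorophenyl in place of 2,4-dichlorophenyl on a carbonyl carbon. Given that the earlier step, a 1.4-fold lower number from compound 2 to compound 1 (0.16 log units; within the scatter), was small, the step expected from compound 3 to compound 4 is also expected to be small, a 1.3-fold lower number from compound 3 to compound 4 (0.10 log units; within the scatter). Compound 4 is therefore estimated at 5 ug/mL, with a likely range from 2.5 ug/mL to 10 ug/mL.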

Compound 4, half-maximal inhibitory concentration: 19.5 ug/mL
The estimate for compound 4 lay 3.9-fold (0.59 log units) below the measured number; measured number outside the range, above it.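

In this assay, 3-(trifluoromethyl)phenyl in place of 2-(trifluoromethyl)phenyl gave a 3.1-fold higher number from compound 3 to compound 4 (0.49 log units; beyond the scatter), and this step does not match the one seen earlier for the same change: the same change on two cores in this assay, a 1.4-fold lower number (0.16 log units; within the scatter) from compound 2 to compound 1 and a 3.1-fold higher number (0.49 log units; beyond the scatter) from compound 3 to compound 4, 4.5-fold (0.65 log units) apart, beyond the scatter of two such steps The other change, 2-fluorophenyl in place of 2,4-dichlorophenyl on a carbonyl carbon, gave a 1.8-fold higher number from compound 1 to compound 4 (0.26 log units; within the scatter), and it too fails to carry over: the same change on two cores in this assay, a 2.4-fold lower number (0.38 log units; beyond the scatter) from compound 2 to compound 3 and a 1.8-fold higher number (0.26 log units; within the scatter) from compound 1 to compound 4, 4.5-fold (0.65 log units) apart, beyond the scatter of two such steps Both comparisons rest on the same four compounds and so describe a single mismatch seen from two sides; this shows that neither step could be moved as a fixed amount between these cores, but it does not show why the steps differ or how either change would behave on any other core.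

The compounds shown leave open whether the mismatch persists when the trifluoromethyl on the phenyl is replaced by a nitrile or a methoxy group. They also leave open what happens when an unsubstituted phenyl stands on the carbonyl carbon.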